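The source may report more compounds than this note shows. Statements on the series, on what has been measured and on what is new or still open speak of the compounds shown alone.

Compound 3 `Cc1ccccc1-c1nn(-c2cc(F)ccc2F)cc1CNCCN1CCN(C)CC1` — > 20000 nM
Compound 2 `CN1CCN(CCNCc2cn(-c3ccc(F)cc3F)nc2-c2ccccc2)CC1` — > 20000 nM
Compound 1 `CN1CCN(CCNCc2cn(-c3ccc([N+](=O)[O-])cc3)nc2-c2ccc(C(F)(F)F)cc2)CC1` — 3200 nM

In an ADME assay on Huh-7 cells (Homo sapiens) for cytotoxicity (a higher number here means that more compound is tolerated, a lower number that less compound is tolerated), compound 3 gives only a limit, > 20000 nM. Compound 2 likewise gives only a limit, > 20000 nM. Compound 1 alone gives a number, 3200 nM. Compound 3 therefore stands at the limit of > 20000 nM in this assay, at which 2 of the 3 values shown sit, and nothing separates it from compound 2 on these numbers.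

Compound 4 `Cc1ccccc1-c1nn(-c2ccc(C(F)(F)F)cc2)cc1CNCCN1CCN(C)CC1` is not yet measured; it differs from compound 3 by 4-(trifluoromethyl)phenyl in place of 2,5-difluorophenyl on an aromatic nitrogen. Among the measured compounds shown here, no two measured compounds differ in a single place, so no step size is known. Since compound 3 sits at the limit of > 20000 nM in this assay, at which 2 of the 3 values shown sit, only a downward move could be seen. Compound 1, which also bears a 4-(trifluoromethyl)phenyl group, gives 3200 nM. The expected step is small, an at least 1.4-fold lower number from compound 3 to compound 4 (0.15 log units; that floor lies within the scatter), with a fair chance that this assay again reports only a limit. Compound 4 is estimated at 14000 nM, within 4000 nM to 30000 nM.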

Compound 4, half-maximal cytotoxic concentration: 11000 nM
Beside the measured number, compound 4's estimate is 1.3-fold (0.10 log units) above it; measured number inside the range.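

Exchanging 2,5-difluorophenyl for 4-(trifluoromethyl)phenyl on the aromatic nitrogen gives, in this assay, an at least 1.8-fold lower number from compound 3 to compound 4 (0.25 log units; that floor lies within the scatter). Among the compounds shown here, this is the first step read at this position, and it shows only a floor that does not clear the scatter. Compound 4 gives a number, but the true size of the step stays unknown, since compound 3 gives only a limit: the limit of > 20000 nM in this assay, at which 2 of the 4 values shown sit.

Still open, as far as these compounds go, is how a methoxy group or a nitrile on this phenyl ring would read. Also open, from the compounds shown here alone, is whether the same exchange gives a similar step without the 2-methylphenyl group.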